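A Second Benzylamino Group on a Fluorinated Core

The source may hold more compounds than are shown below. What is called first, only, known or untested is meant among the compounds shown, and "the series" means these compounds.

Compound 1 `N#Cc1c(F)c(F)c2nc(N)nc(N)c2c1F` is the parent of this small set. In a functional assay on HepG2 cells (Homo sapiens) for cytotoxicity, read by MTT assay (on this read-out higher numbers stand for weaker inhibition and lower numbers for stronger inhibition), compound 1 gives 5 ug/mL. Compound 2 `N#Cc1c(NCc2ccccc2)c(F)c2nc(N)nc(N)c2c1F` carries a benzylamino group where compound 1 has a fluorine, and in this assay compound 2 gives 27.8 ug/mL. That single exchange gave a 5.6-fold higher number from compound 1 to compound 2 (0.75 log units; beyond the scatter). Among the two numbers known so far, compound 2 therefore stands highest, with compound 1 as its only neighbour.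

Compound 3 `N#Cc1c(NCc2ccccc2)c(F)c2nc(N)nc(N)c2c1NCc1ccccc1` takes the same kind of exchange one place further: benzylamino in place of fluoro on an aromatic carbon. Among the measured compounds shown here, the only measured step that bears on this change is the one from compound 1 to compound 2, a modest rise beyond the scatter, and it concerns the same replacement of fluoro by benzylamino on the same core. For the measured compounds named here, no second example of the exchange exists, so a repeat is expected to move the number in this assay in the same direction, by a step of similar or somewhat smaller size. For compound 3 the expected step is a 2.9-fold higher number from compound 2 to compound 3 (0.46 log units; beyond the scatter). Compound 3 is thus estimated at 80 ug/mL, within a range from 35 ug/mL to 180 ug/mL.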

Compound 3, half-maximal inhibitory concentration: 13.4 ug/mL
Compound 3: middle estimate off by 6.0-fold (0.78 log units), on the high side; measured number outside the range, below it.
By their numbers in this assay, from the lowest: compound 1; then compound 3; then compound 2.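

In this assay, the exchange of fluoro for benzylamino does not act in a single direction on this core: the earlier exchange gave a 5.6-fold higher number from compound 1 to compound 2 (0.75 log units; beyond the scatter), whereas the exchange at this carbon, ortho to a cyano group and para to a fluoro group, gave a 2.1-fold lower number from compound 2 to compound 3 (0.32 log units; beyond the scatter). Both steps lie beyond the scatter, so the outcome of this change depends on where it is made, on which groups the ring already carries, or on both, which the first pair alone could not show. No measurement at hand accounts for the reversal in direction.

The compounds shown leave open whether benzylamino at this carbon would give a lower number if the other fluoro groups of compound 1 remained in place, which would separate the effect of this position from that of the benzylamino group already present in compound 2. They also leave open whether the benzyl ring matters to the number here, or whether a small amine such as methylamino, or a longer chain such as phenethylamino, would move it in the same direction.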